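The source may hold more compounds than are shown below. What is called first, only, known or untested is meant among the compounds shown, and "the series" means these compounds.

Measured in a functional assay on HOP-62 cells (Homo sapiens) for inhibition, read by sulforhodamine B assay; a higher number here means a weaker inhibitor of growth, a lower number a stronger inhibitor of growth:
- compound 1 `Fc1ccc(-c2ccc(-c3ccc(-c4nc5ccccc5[nH]4)cc3)cc2)cc1`: 39300 nM
- compound 2 `FC(F)(F)Oc1ccc(-c2ccc(-c3ccc(-c4nc5ccccc5[nH]4)cc3)cc2)cc1`: 100000 nM
- compound 3 `Oc1cccc2[nH]c(-c3ccc(-c4ccc(-c5ccc(F)cc5)cc4)cc3)nc12`: 8310 nM

Compound 3 has the lowest number of the three. Compound 4 `Oc1cccc2[nH]c(-c3ccc(-c4ccc(-c5ccc(OC(F)(F)F)cc5)cc4)cc3)nc12` differs from it by trifluoromethoxy in place of fluoro on an aromatic carbon, para to a large group: trifluoromethoxy in place of fluoro on an aromatic carbon.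

Among the measured compounds shown here, two measured steps bear on this. The same exchange, seen once, gave a 2.5-fold higher number from compound 1 to compound 2 (0.41 log units; beyond the scatter). The hydroxy that compound 3 and compound 4 share gave a 4.7-fold lower number from compound 1 to compound 3 (0.67 log units; beyond the scatter). On that single exchange, a modest step toward a higher number is expected in this assay. The estimated step is a 2.5-fold higher number from compound 3 to compound 4 (0.40 log units; beyond the scatter). For compound 4 the estimated value is 21000 nM, with an expected range of 8000 nM to 60000 nM.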

Compound 4, concentration for 50% growth inhibition: 2270 nM
Compound 4: the middle estimate sits 9.3-fold (0.97 log units) above what was measured; measured number below the stated range.
By their numbers in this assay, from the lowest: compound 4; then compound 3; then compound 1; then compound 2.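

With the hydroxy present, trifluoromethoxy in place of fluoro lowers the number in this assay, a 3.7-fold lower number from compound 3 to compound 4 (0.56 log units; beyond the scatter), so the exchange at this position does not carry over from one core to the other: the same change on two cores in this assay, a 2.5-fold higher number (0.41 log units; beyond the scatter) from compound 1 to compound 2 and a 3.7-fold lower number (0.56 log units; beyond the scatter) from compound 3 to compound 4, 9.3-fold (0.97 log units) apart, beyond the scatter of two such steps. Read the other way, adding the hydroxy gives a larger step with trifluoromethoxy, a 44-fold lower number from compound 2 to compound 4 (1.64 log units; beyond the scatter), than with fluoro: the same change on two cores in this assay, a 4.7-fold lower number (0.67 log units; beyond the scatter) from compound 1 to compound 3 and a 44-fold lower number (1.64 log units; beyond the scatter) from compound 2 to compound 4, 9.3-fold (0.97 log units) apart, beyond the scatter of two such steps. The two changes therefore do not add independently across these four compounds.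

From the compounds shown here alone, whether the lower number with the hydroxy core extends to other groups at this position, such as an amine or a nitrile, remains open. Two groups at this position on two cores define no general trend.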